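Dimethylamino for Methoxy on a Hydroxylated Benzimidazole Core

The source may report more compounds than this note shows. Statements on the series, on what has been measured and on what is new or still open speak of the compounds shown alone.

Compound 1 `COc1ccc(-c2ccc(-c3ccc(-c4nc5ccccc5[nH]4)cc3)cc2)cc1` and compound 2 `CN(C)c1ccc(-c2ccc(-c3ccc(-c4nc5ccccc5[nH]4)cc3)cc2)cc1` share one core; in a functional assay on ZR-75-1 cells (Homo sapiens) for inhibition, read by sulforhodamine B assay (on this read-out lower numbers stand for stronger inhibition of growth and higher numbers for weaker inhibition of growth), compound 1 gives 35100 nM and compound 2 gives 100000 nM. The change between them, (dimethylamino in place of methoxy on an aromatic carbon), made a 2.8-fold higher number from compound 1 to compound 2 (0.45 log units; beyond the scatter). Compound 3 `COc1ccc(-c2ccc(-c3ccc(-c4nc5c(O)cccc5[nH]4)cc3)cc2)cc1` carries a different core, set apart from that of compound 1 by hydroxy in place of hydrogen on an aromatic carbon; in this assay compound 3 gives 8200 nM, and that change made a 4.3-fold lower number from compound 1 to compound 3 (0.63 log units; beyond the scatter). Compound 4 `CN(C)c1ccc(-c2ccc(-c3ccc(-c4nc5c(O)cccc5[nH]4)cc3)cc2)cc1` is compound 3 with the same change as before, (dimethylamino in place of methoxy on an aromatic carbon), at the same place. Because a 2.8-fold higher number from compound 1 to compound 2 (0.45 log units; beyond the scatter) was modest, the step from compound 3 to compound 4 is expected to be similar, a 2.8-fold higher number from compound 3 to compound 4 (0.45 log units; beyond the scatter). Compound 4 is therefore estimated at 23000 nM, between 9000 nM and 60000 nM.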

Compound 4, concentration for 50% growth inhibition: 4100 nM
Compound 4: middle estimate off by 5.6-fold (0.75 log units), on the high side; measured number below the stated range.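

In this assay the change from methoxy to dimethylamino gave a 2.0-fold lower number from compound 3 to compound 4 (0.30 log units; within the scatter) and so did not repeat the step seen on the core of compound 1: the same change on two cores in this assay, a 2.8-fold higher number (0.45 log units; beyond the scatter) from compound 1 to compound 2 and a 2.0-fold lower number (0.30 log units; within the scatter) from compound 3 to compound 4, 5.7-fold (0.76 log units) apart, beyond the scatter of two such steps. Read the other way, adding the hydroxy group gave a 24-fold lower number from compound 2 to compound 4 (1.39 log units; beyond the scatter) and its step also depended on the group at the far end: the same change on two cores in this assay, a 4.3-fold lower number (0.63 log units; beyond the scatter) from compound 1 to compound 3 and a 24-fold lower number (1.39 log units; beyond the scatter) from compound 2 to compound 4, 5.7-fold (0.76 log units) apart, beyond the scatter of two such steps. In these four compounds, then, a step measured on one core did not carry over to the other, but a single pair on each core does not show why, nor whether this holds on any further core.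

The compounds shown leave open how an unsubstituted amine or a longer ether chain in that place would behave on either core. They also leave open what the hydroxy group would do elsewhere on the core.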